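The compounds below may be only part of what the source reports. "The series", "measured", "known", "first", "only" and "open" are said of these compounds alone.

Three related compounds have been tested for how strongly they hold back the growth of a liver cancer cell line. Compound 1 `Cc1ccc(SCc2ccc(/C=C/C(=O)Nc3ccccc3N)cc2)cc1`, compound 2 `Nc1ccccc1NC(=O)c1ccc(CSc2ccc(Br)cc2)cc1` and compound 3 `Nc1ccccc1NC(=O)/C=C/c1ccc(CSc2ccc(Cl)cc2)cc1` share one core and differ only in the group hanging off the sulfur. In a functional assay on SMMC-7721 cells (Homo sapiens) for inhibition, read by CCK-8 assay, with a stated time of 72 h, tested at 2 uM (a higher number here means more inhibition of growth at the concentration tested, a lower number less inhibition of growth), compound 1 gives 22%. In this assay compound 2 gives 10%, and compound 3 gives 15.2%. Compound 3 thus has the second highest of the three numbers, yet its gaps to compound 2 and to compound 1 both lie within the usual scatter, so the three cannot be ranked. Going by the values given here, the one step between compounds differing in a single place is a number 6.8 percentage points lower from compound 1 to compound 3 (within the scatter), a change that stayed within the scatter.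

Compound 4 `Nc1ccccc1NC(=O)/C=C/c1ccc(CSc2cccc(F)c2)cc1` now differs from compound 3 by 3-fluorophenyl in place of 4-chlorophenyl on a sulfur. Among the compounds with values here, no measured step swaps one halogen for another or shifts it on the ring, so the expectation rests on the flat step just described. Compound 4 is therefore expected to give about 15%, with a range from 5% to 28%. That estimate amounts to an expected step of a number 0.2 percentage points lower from compound 3 to compound 4 (within the scatter), not beyond the scatter.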

Compound 4, percent growth inhibition at one concentration: 8.56%
Beside the measured number, compound 4's estimate is 6.4 percentage points above it, and the stated range covers the measured number.
By their numbers in this assay, from the lowest: compounds 4, 2, 3 and 1 (each within the scatter of the next, the first and the last beyond it).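

Going by these compounds alone, the sulfur substituent can shift growth inhibition: in this assay, 3-fluorophenyl in place of 4-methylphenyl gives a number 13.4 percentage points lower from compound 1 to compound 4 (beyond the scatter), the only step so far that lies beyond the usual scatter, although it is modest. By contrast, 3-fluorophenyl in place of 4-chlorophenyl gives a number 6.6 percentage points lower from compound 3 to compound 4 (within the scatter), so these two halogen-bearing rings cannot be told apart here. Nothing available explains the larger step.

Going by these compounds, both steps change the group on the ring and its place together, so the contribution of each remains unknown. The compounds shown also leave open how a 4-fluorophenyl group, a plain phenyl group, or a phenyl ring carrying an amine or a carboxylic acid would behave on the sulfur.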